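Aryl swap on the amidine of compound 1: compound 4

The compounds below may be only part of what the source reports. "The series", "measured", "known", "first", "only" and "open" are said of these compounds alone.

Three compounds of the shared core have numbers in an assay on nucleic acid for binding affinity to Salmon testes DNA (Salmonidae), tested at 10 uM; a higher number here means that the compound stabilises the target more against heat, a lower number that the compound stabilises the target less. Compound 1 `CC(C)CCc1sc(NC(=O)c2cc(NC(=O)c3cc(NC(=N)c4cccc(F)c4)cn3C)cn2C)nc1C(=O)NCCCN(C)C` gives 4 degrees C and stands lowest of the three. Compound 2 `CN(C)CCCNC(=O)c1cc(NC(=O)c2cc(NC(=O)c3cc(NC(=N)N)cn3C)cn2C)cn1C` gives 5 degrees C, which lies within the scatter of the number for compound 1, so no order between these two is claimed. Compound 3 `CC(C)CCn1cc(NC(=O)c2cc(NC(=O)c3cc(NC(=N)c4ccccc4)cn3C)cn2C)cc1C(=O)NCCCN(C)C` gives 8 degrees C, and its gap to compound 1 is beyond the scatter. Compounds 2 and 3 each differ from compound 1 in more than one place, so none of these gaps is a single step and no cause is read into them.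

Compound 4 `CC(C)CCc1sc(NC(=O)c2cc(NC(=O)c3cc(NC(=N)c4ccc(Cl)cc4)cn3C)cn2C)nc1C(=O)NCCCN(C)C` has not yet been measured in this assay. It differs from compound 1 by 4-chlorophenyl in place of 3-fluorophenyl on a carbon with a double bond to nitrogen. No measured pair in this set changes only that ring, so the size of the step has no shown step behind it. The group that enters matches the group that leaves in what is counted, and everything else in compound 1 is kept, so the step is expected to be small, with no clear direction and likely none beyond the scatter. The step of a number 0.50 degrees C higher from compound 1 to compound 4 (within the scatter) is the estimate that follows. In this assay compound 4 is expected to give about 4.5 degrees C, with a range from 2.5 degrees C to 7 degrees C.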

Compound 4, shift of the target's melting temperature: 4 degrees C
Beside the measured number, compound 4's estimate is 0.50 degrees C above it, within the range that was stated.
By their numbers in this assay, from the lowest: compounds 1, 4 and 2 (each within the scatter of the next); then compound 3.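

In this assay, 4-chlorophenyl in place of 3-fluorophenyl on a carbon with a double bond to nitrogen gives no change at the digits printed from compound 1 to compound 4 (within the scatter), the only single-place step among the compounds shown. Among the compounds shown here, it provides the first direct reading at this position: for this pair, one halogen-bearing phenyl ring can replace the other, with the same count of heavy atoms and no hydrogen-bond donors or acceptors on either, without a change that can be separated from the scatter. No measurement bears on why the read-out holds for this exchange.

The result covers this one pair of rings and does not show whether the read-out is insensitive to the halogen, to its place on the ring, or to both, or whether an amine or a carboxylic acid on the phenyl ring would give a step beyond the scatter. On these data alone, the remaining gaps cannot be read as steps, as compound 2 and compound 3 each differ from compound 1 in more than one place, so the contribution of the rest of the structure stays open.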